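Extending a hydroxamate chain on two related cores

This account rests on a few compounds, and the source may have more. Where it says the series, first, only, none or still open, it means among the compounds named here.

Compound 1 `Nc1ncnc2c1c(-c1cnc3[nH]ccc3c1)nn2CCCCCCCCC(=O)NO` and compound 2 `Nc1ncnc2c1c(-c1cnc3[nH]ccc3c1)nn2CCCCCC(=O)NO` share one core, while compound 3 `Nc1nc2cc(-c3nn(CCCCCC(=O)NO)c4ncnc(N)c34)ccc2o1` carries another; the difference between the two cores is not broken down here. In a functional assay on MDA-MB-231 cells (Homo sapiens) for inhibition, read by MTT assay, with a stated time of 72 h (a higher number here means a weaker inhibitor, a lower number a stronger inhibitor), compound 1 gives 11000 nM. Compound 2 gives only a limit of > 100000 nM in this assay. Compound 3 gives 19000 nM in this assay. The change from compound 2 to compound 1 is 3-(hydroxycarbamoyl)propyl in place of hydroxycarbamoyl on a saturated chain carbon, five bonds along the chain from an aromatic nitrogen and yields an at least 9.0-fold lower number from compound 2 to compound 1 (0.95 log units; beyond the scatter), a size that rests on (the limit of > 100000 nM in this assay, at which 1 of the 3 values shown sits). The same change, (3-(hydroxycarbamoyl)propyl in place of hydroxycarbamoyl on a saturated chain carbon, five bonds along the chain from an aromatic nitrogen), turns compound 3 into compound 4 `Nc1nc2cc(-c3nn(CCCCCCCCC(=O)NO)c4ncnc(N)c34)ccc2o1`, not yet measured in this assay. Because the step of an at least 9.0-fold lower number from compound 2 to compound 1 (0.95 log units; beyond the scatter) lowers the number, compound 4 is expected to show a 6.3-fold lower number from compound 3 to compound 4 (0.80 log units; beyond the scatter) in this assay. Compound 4 is estimated at 3000 nM, between 800 nM and 12000 nM.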

Compound 4, half-maximal inhibitory concentration: 30300 nM
Beside the measured number, compound 4's estimate is 10-fold (1.00 log units) below it; measured number outside the range, above it.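

In this assay the longer chain gives a 1.6-fold higher number from compound 3 to compound 4 (0.20 log units; within the scatter), so the change that lowered the number on the other core does not carry over to this one: the same change on two cores in this assay, an at least 9.0-fold lower number (0.95 log units; beyond the scatter) from compound 2 to compound 1 and a 1.6-fold higher number (0.20 log units; within the scatter) from compound 3 to compound 4, at least 14-fold (1.16 log units) apart, beyond the scatter of two such steps

Compound 2 gives > 100000 nM, which is a limit of the assay and not a number, and the size of the earlier step rests on it: the limit of > 100000 nM in this assay, at which 1 of the 4 values shown sits.

With the longer chain on both cores, the change of core gives a 2.8-fold higher number from compound 1 to compound 4 (0.44 log units; beyond the scatter), yet two cores alone cannot show why the chain change acts on one and not on the other, nor how it would act on a third.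

From the compounds shown here alone, whether a still longer chain, or a carboxylic acid in place of the hydroxycarbamoyl group, would behave alike on both cores stays open.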